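This account rests on a few compounds, and the source may have more. Where it says the series, first, only, none or still open, it means among the compounds named here.

In a functional assay on A549 cells (Homo sapiens) for cytotoxicity, with a stated time of 48 h (on this read-out lower numbers stand for stronger inhibition and higher numbers for weaker inhibition), three compounds sharing one core have been measured. Compound 1 `CCCCC(=O)Oc1ccc2oc(/C=C/[S+](C)[O-])cc(=O)c2c1` gives 2400 nM, compound 2 `CC(C)CCOc1ccc2oc(/C=C/[S+](C)[O-])cc(=O)c2c1` gives 1000 nM, and compound 3 `C[S+]([O-])/C=C/c1cc(=O)c2cc(Cl)ccc2o1` gives 1700 nM. Compound 3 lies within the scatter of both others, as shown by a 1.4-fold lower number from compound 1 to compound 3 (0.15 log units; within the scatter) and by a 1.7-fold higher number from compound 2 to compound 3 (0.23 log units; within the scatter). Only a 2.4-fold lower number from compound 1 to compound 2 (0.38 log units; beyond the scatter) goes beyond the scatter.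

The next compound is compound 4 `CCC(=O)Oc1ccc2oc(/C=C/[S+](C)[O-])cc(=O)c2c1`, with propanoyloxy in place of chloro on an aromatic carbon. The nearest measured parallel is compound 1, which carries (butylcarbonyl)oxy on that carbon. Its exchange for chloro stayed within the scatter, and this reverse change would therefore be expected to do the same. The step to compound 2 shows that a different group on this oxygen can move the number modestly, so the range should stay wide. For the measured compounds named here, no measured pair compares propanoyl with butylcarbonyl directly.

In this assay, no step beyond the scatter is therefore expected, with at most a slightly higher number. The estimated change is a 1.2-fold higher number from compound 3 to compound 4 (0.07 log units; within the scatter). For compound 4 the expected value is 2000 nM, with an estimated range from 900 nM to 4500 nM.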

Compound 4, half-maximal inhibitory concentration: 2400 nM
Beside the measured number, compound 4's estimate is 1.2-fold (0.08 log units) below it, and the stated range covers the measured number.
By their numbers in this assay, from the lowest: compounds 2, 3, 1 and 4 (each within the scatter of the next, the first and the last beyond it).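

In this assay, shortening the ester chain from (butylcarbonyl)oxy to propanoyloxy leaves the number unmoved (no change at the digits printed from compound 1 to compound 4 (within the scatter)), which gives this aromatic carbon its first direct comparison of two esters and shows no effect of this chain trimming. Chloro and propanoyloxy also cannot be told apart on this carbon (a 1.4-fold higher number from compound 3 to compound 4 (0.15 log units; within the scatter)), so the exchange between a single halogen atom and the larger ester group does not register beyond the scatter here. Isopentyl in place of propanoyl on the oxygen does give a modest separation (a 2.4-fold higher number from compound 2 to compound 4 (0.38 log units; beyond the scatter)), so the gap first seen with the (butylcarbonyl)oxy compound recurs with a second ester, although chloro, lying within the scatter of both the ether and the esters, fits neither side of that split.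

On these data alone, whether an amine or a carboxylic acid on this carbon, or an ester chain longer than (butylcarbonyl)oxy, would move the number beyond the scatter remains open. Nothing is available that would explain any of these steps.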